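A few compounds are considered here, and "the series" means these few. Any claim that something is new, unique, unknown or untested is made for them only; others in the source may bear on it.

Compound 1 `NCCCCCCOc1ccc2c(=O)c(-c3ccc(O)cc3)coc2c1`: 100 nM
Compound 2 `CC(Oc1ccc2c(=O)c(-c3ccc(O)cc3)coc2c1)C(=O)O`: 2500 nM

The two measured compounds share one core and differ only in the group carried on an oxygen on an aromatic ring. In an assay (Cricetulus griseus) for inhibition of aldehyde dehydrogenase, mitochondrial (Homo sapiens) (a higher number here means a weaker inhibitor, a lower number a stronger inhibitor), compound 1 gives 100 nM, the lowest of the two numbers, and compound 2 gives 2500 nM. Within the data shown here, the single measured step, a 25-fold higher number from compound 1 to compound 2 (1.40 log units; beyond the scatter), puts 1-carboxyethyl in place of 6-aminohexyl on an oxygen on an aromatic ring. Compound 3 `O=C(O)CCCCCCCCCCCOc1ccc2c(=O)c(-c3ccc(O)cc3)coc2c1` keeps the chain of compound 1 and alters it at a saturated chain carbon, six bonds along the chain from an oxygen on an aromatic ring: 5-carboxypentyl in place of amino on a saturated chain carbon, six bonds along the chain from an oxygen on an aromatic ring. The step from compound 1 to compound 2 bears on this change only in part, since it exchanges the whole chain rather than adding to it, whereas compound 3 retains the chain and gains a carboxylic acid. Among the measured compounds shown here, a higher number than for compound 1 is therefore expected, but a smaller rise than the one seen for compound 2. Compound 3 is expected to give 300 nM, with a range of 80 nM to 1500 nM, which would mean a step of a 3.0-fold higher number from compound 1 to compound 3 (0.48 log units; beyond the scatter).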

Compound 3, half-maximal inhibitory concentration: 130 nM
Estimate against measurement, compound 3: 2.3-fold (0.36 log units) above, and the stated range covers the measured number.
By their numbers in this assay, from the lowest: compounds 1 and 3 (each within the scatter of the next); then compound 2.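

In this assay, the step of a 1.3-fold higher number from compound 1 to compound 3 (0.11 log units; within the scatter) shows that the amino group at the end of the chain of compound 1 can give way to 5-carboxypentyl and the two numbers still cannot be told apart. This changes how the earlier step, a 25-fold higher number from compound 1 to compound 2 (1.40 log units; beyond the scatter), can be read: compound 2 also carries a carboxylic acid, but it has 1-carboxyethyl where compound 1 has the whole 6-aminohexyl chain, so that step could not show what a carboxylic acid does at the end of an intact chain, and compound 3 now shows that such an acid there comes with a number close to that of compound 1. Nothing given here explains why these two compounds read alike.

Compound 3 differs from compound 1 in both the end group and the chain length, so the compounds shown cannot separate the two, and a carboxylic acid on a chain the length of the one in compound 1 would be needed to do that. As far as these compounds go, it also remains open whether any group is needed at the chain end at all, which a plain alkyl chain or a chain ending in a hydroxyl would test.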